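Shortening the amide linker on the indole-based series

A few compounds are considered here, and "the series" means these few. Any claim that something is new, unique, unknown or untested is made for them only; others in the source may bear on it.

Measured compounds:
`CC(C)n1c(=O)n(C(=O)NCC2CCNCC2)c2ccccc21` compound 1, 39.8 nM
`CC(C)n1c(=O)n(C(=O)NC2CCNCC2)c2ccccc21` compound 2, 1580 nM
`COc1ccc2[nH]cc(C(=O)NCC3CCNCC3)c2c1` compound 3, 3980 nM

In an assay on HEK293 cells for displacement of a labelled ligand from 5-hydroxytryptamine receptor 4 (Homo sapiens), read by scintillation counting (on this read-out lower numbers stand for stronger inhibition and higher numbers for weaker inhibition), compound 3 gives the highest number of the three. Compound 4 `COc1ccc2[nH]cc(C(=O)NC3CCNCC3)c2c1` differs from compound 3 in one place: piperidin-4-yl in place of (piperidin-4-yl)methyl on an amide-type nitrogen. The same change has been measured once already, on the core of compound 1, where a 40-fold higher number from compound 1 to compound 2 (1.60 log units; beyond the scatter). For the measured compounds named here, that single step is the only evidence bearing on compound 4, and it points to a large rise in this assay. Compound 4 is therefore expected to give a markedly higher number than compound 3, with the step estimated at a 15-fold higher number from compound 3 to compound 4 (1.18 log units; beyond the scatter). The estimate for compound 4 is 60000 nM, within a range from 15000 nM to 250000 nM.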

Compound 4, inhibition constant: 3160 nM
Estimate against measurement, compound 4: 19-fold (1.28 log units) above; the whole stated range lies above it.
By their numbers in this assay, from the lowest: compound 1; then compounds 2, 4 and 3 (each within the scatter of the next, the first and the last beyond it).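

In this assay, piperidin-4-yl in place of (piperidin-4-yl)methyl on the amide-type nitrogen gives a 1.3-fold lower number from compound 3 to compound 4 (0.10 log units; within the scatter), so on this core the change has no readable effect. The earlier compounds had shown this change only as a large rise in the number. The size of its effect therefore differs with the core that carries it: the same change on two cores in this assay, a 40-fold higher number (1.60 log units; beyond the scatter) from compound 1 to compound 2 and a 1.3-fold lower number (0.10 log units; within the scatter) from compound 3 to compound 4, 50-fold (1.70 log units) apart, beyond the scatter of two such steps

The compounds shown leave open whether a longer chain carrying piperidin-4-yl on that nitrogen would behave alike on both cores. They also leave open which feature of the cores sets this difference.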